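Swapping an amide substituent on a quinoline ether series

The source may report more compounds than this note shows. Statements on the series, on what has been measured and on what is new or still open speak of the compounds shown alone.

Measured so far:
compound 1 `COc1ccc2nc(C)cc(OCc3ccc4ccccc4n3)c2c1` — 5.48
compound 2 `COc1ccc(NC(=O)COc2cc(C)nc3ccc(OC)cc23)cc1` — 4.22

Of the compounds shown here, two have been measured in a physicochemical assay for lipophilicity, read by HPLC, in phosphate buffer, measured as chromatographic lipophilicity, at pH 7.4; on this read-out higher numbers stand for higher lipophilicity and lower numbers for lower lipophilicity. Compound 1 `COc1ccc2nc(C)cc(OCc3ccc4ccccc4n3)c2c1` gives 5.48, and compound 2 `COc1ccc(NC(=O)COc2cc(C)nc3ccc(OC)cc23)cc1` gives 4.22, which is the lower of the two numbers, a gap that lies beyond the usual scatter. Among the compounds with values here, no step between a pair of measured compounds that differ in a single place is available, so nothing is known yet about how single changes move this read-out.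

Compound 3 `COc1ccc2nc(C)cc(OCC(=O)Nc3nc(C)c(C)s3)c2c1` is the next compound to be measured in this assay. It differs from compound 2 as follows: 4,5-dimethyl-1,3-thiazol-2-yl in place of 4-methoxyphenyl on an amide-type nitrogen.

Within the data shown here, with no comparable step recorded, the move from compound 2 to compound 3 is expected to be small, around a number 0.12 log units lower from compound 2 to compound 3 (within the scatter), and not clearly beyond the scatter in either direction. Starting from the value of compound 2, 4.22, compound 3 is therefore expected to give about 4.1, with a plausible range from 3.6 to 4.6.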

Compound 3, distribution coefficient: 4.24
Compound 3: middle estimate off by 0.14 log units, on the low side, within the range that was stated.
By their numbers in this assay, from the lowest: compounds 2 and 3 (each within the scatter of the next); then compound 1.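

Swapping 4-methoxyphenyl for 4,5-dimethyl-1,3-thiazol-2-yl on the amide-type nitrogen gives the first single-place comparison in this set: in this assay the swap amounts to a number 0.02 log units higher from compound 2 to compound 3 (within the scatter). At this position, then, a five-membered aromatic ring with 2 hetero atoms and a six-membered aromatic ring of carbon only give numbers that cannot be told apart in this read-out, although the two groups differ in their atoms. Nothing available explains why the two compounds read alike.

Still open, as far as these compounds go, is what each part of the entering group contributes, for instance how a plain thiazol-2-yl without the two methyl groups would read. Also open, from the compounds shown here alone, is whether quite different groups on this nitrogen, such as a cyclohexyl ring or a carboxylic acid chain, would stay equally close.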